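This account rests on a few compounds, and the source may have more. Where it says the series, first, only, none or still open, it means among the compounds named here.

Compound 1 `Cc1cccc(/C(N)=N/NC(=S)N2CCSCC2)n1` was examined in a functional assay on MCF7 cells (Homo sapiens) for cytotoxicity, read by MTT assay, with a stated time of 72 h, tested at 3 uM (on this read-out lower numbers stand for less inhibition of growth and higher numbers for more inhibition of growth at the one concentration tested), where compound 1 gives 20.6%. Compound 2 `N/C(=N\NC(=S)N1CCSCC1)c1ccccn1` differs from it by hydrogen in place of methyl on an aromatic carbon, and in this assay compound 2 gives 29%; the step of a number 8.4 percentage points higher from compound 1 to compound 2 (within the scatter) lies within the scatter. Compound 3 `Cc1cccc(/C(N)=N/NC(=S)N2CCCC2)n1` carries a different core: the difference is pyrrolidin-1-yl in place of thiomorpholin-4-yl on a thiocarbonyl carbon, and in this assay compound 3 gives 26.6%, with the step of a number 6 percentage points higher from compound 1 to compound 3 (within the scatter) again within the scatter. Compound 4 `N/C(=N\NC(=S)N1CCCC1)c1ccccn1` has not yet been measured. It stands to compound 3 as compound 2 stands to compound 1: the change is hydrogen in place of methyl on an aromatic carbon, the same change that was made from compound 1 to compound 2, occurring twice among these four compounds, and at the same place in both pairs. Since the earlier step of a number 8.4 percentage points higher from compound 1 to compound 2 (within the scatter) stayed within the scatter, compound 4 is expected to show a step of a number 5.4 percentage points higher from compound 3 to compound 4 (within the scatter), resting on that earlier step alone. On this basis compound 4 is estimated at 32% in this assay, between 21% and 43%.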

Compound 4, percent growth inhibition at one concentration: 49.8%
Compound 4: the middle estimate sits 17.8 percentage points below what was measured; the measured number lies above the stated range.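

In this assay hydrogen in place of methyl on an aromatic carbon gives a number 23.2 percentage points higher from compound 3 to compound 4 (beyond the scatter), so this change did not keep its size on moving to the pyrrolidin-1-yl core: the same change on two cores in this assay, a number 8.4 percentage points higher (within the scatter) from compound 1 to compound 2 and a number 23.2 percentage points higher (beyond the scatter) from compound 3 to compound 4, 14.8 percentage points apart, beyond the scatter of two such steps. Pyrrolidin-1-yl in place of thiomorpholin-4-yl on a thiocarbonyl carbon gives a number 20.8 percentage points higher from compound 2 to compound 4 (beyond the scatter), and it likewise depends on the group at the other place: the same change on two cores in this assay, a number 6 percentage points higher (within the scatter) from compound 1 to compound 3 and a number 20.8 percentage points higher (beyond the scatter) from compound 2 to compound 4, 14.8 percentage points apart, beyond the scatter of two such steps. These two comparisons rest on the same four compounds, so they show that the two changes do not add up independently in this set, but they do not show why, or whether this holds beyond these compounds or at other concentrations.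

The compounds shown leave open whether a piperidin-1-yl or morpholin-4-yl group on the thiocarbonyl carbon would behave like pyrrolidin-1-yl. They also leave open what an ethyl group or a chlorine atom in place of the methyl would do on either core.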